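Removing One Methoxy Group: A Matched Pair and Its Echo

The source may hold more compounds than are shown below. What is called first, only, known or untested is meant among the compounds shown, and "the series" means these compounds.

Of the compounds shown here, three have been tested in a functional assay on OVCAR-4 cells (Homo sapiens) for cytotoxicity, read by sulforhodamine B assay, with a stated time of 48 h, tested at 0.01 uM; on this read-out higher numbers stand for a weaker effect at the one concentration tested and lower numbers for a stronger effect. Compound 1 `COc1cc(-c2cc(/C=C/C(=O)c3ccc(N)cc3)[nH]n2)cc(OC)c1OC` gives 85%, and compound 2 `COc1ccc(-c2cc(/C=C/C(=O)c3ccc(N)cc3)[nH]n2)cc1OC` gives 85%. The change from compound 1 to compound 2 is hydrogen in place of methoxy on an aromatic carbon, and it produced no change at the digits printed from compound 1 to compound 2 (within the scatter). Compound 3 `COc1cc(C(=O)/C=C/c2cc(-c3cc(OC)c(OC)c(OC)c3)n[nH]2)cc(OC)c1OC` gives 95% in this assay, the highest of the three numbers, although its gap to compound 1 and to compound 2 lies within the scatter, so no order among them can be claimed. The difference between the core of compound 3 and the core of compound 1 is not broken down here.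

Compound 4 `COc1ccc(-c2cc(/C=C/C(=O)c3cc(OC)c(OC)c(OC)c3)[nH]n2)cc1OC` has not yet been measured in this assay. It differs from compound 3 by hydrogen in place of methoxy on an aromatic carbon, the same change already seen from compound 1 to compound 2, with identical surroundings at the place of change. Because the earlier step gave no change at the digits printed from compound 1 to compound 2 (within the scatter) the expected step here is a number 2 percentage points lower from compound 3 to compound 4 (within the scatter), resting on that single precedent only. Compound 4 is therefore estimated at 93%, most likely between 83% and 100%.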

Compound 4, a percentage reported as activity, at one concentration (the size of the read-out at that concentration, not a potency): 94%
Compound 4: the middle estimate sits 1 percentage points below what was measured; the range from low to high includes it.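

Replacing methoxy with hydrogen on the core of compound 3 gives a number 1 percentage points lower from compound 3 to compound 4 (within the scatter) in this assay. Set beside the earlier case, the two steps agree: the same change on two cores in this assay, no change at the digits printed (within the scatter) from compound 1 to compound 2 and a number 1 percentage points lower (within the scatter) from compound 3 to compound 4, 1 percentage points apart, within the scatter of two such steps. Going by these compounds alone, on these two cores, then, the change carries over with no visible shift in the read-out, but this rests on only two pairs at a single concentration, which measures the size of an effect and not a potency, so it does not show that the same would hold on a third core or at another concentration.

The compounds shown leave open what other groups would do at this place on the ring, such as a hydroxyl group, a fluorine atom or a longer chain like ethoxy in place of methoxy. They also leave open whether removing a methoxy group from elsewhere in these molecules would behave in the same way.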